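Swapping the Sulfonyl Aryl Group in a Glutamate Receptor Series

The compounds below may be only part of what the source reports. "The series", "measured", "known", "first", "only" and "open" are said of these compounds alone.

Compound 1 `CC1CCN(c2c(S(=O)(=O)c3ccc(C#N)cc3)cnc3cc(F)ccc23)CC1` is the reference point. In an assay on isolated protein for displacement of a labelled ligand from metabotropic glutamate receptor 5 (Homo sapiens), with a stated time of 60 min, tested at 1 uM (on this read-out lower numbers stand for less inhibition and higher numbers for more inhibition at the one concentration tested (going by the name of the read-out)), compound 1 gives 83%, the highest of the three numbers measured. Compound 3 `CC1CCN(c2c(S(=O)(=O)c3ccc(C#N)cc3)cnc3cc(Cl)ccc23)CC1` gives 70%, and compound 2 `CC1CCN(c2c(S(=O)(=O)c3cccc(F)c3)cnc3c(F)cccc23)CC1` gives 62%. Within the data shown here, the one step measured between compounds that differ in a single place runs a number 13 percentage points lower from compound 1 to compound 3 (beyond the scatter), for chloro in place of fluoro on an aromatic carbon. Compound 2 differs from compound 1 in more than one place, so its number shows only that it sits lower than compound 1 in this assay.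

Compound 4 `COc1ccc(S(=O)(=O)c2cnc3cc(F)ccc3c2N2CCC(C)CC2)cc1OC` is not yet measured. It differs from compound 1 in one place: 3,4-dimethoxyphenyl in place of 4-cyanophenyl on a sulfonyl sulfur. Among the measured compounds shown here, this change sits on the sulfonyl sulfur, a part of the molecule untouched by the step from compound 1 to compound 3, so no measured step bears directly on it. For the measured compounds named here, the expectation therefore rests on the only single-place step available, a number 13 percentage points lower from compound 1 to compound 3 (beyond the scatter), which was a modest loss at a different place, and a loss of similar size with wide uncertainty is expected here. The expected size of the change is a number 18 percentage points lower from compound 1 to compound 4 (beyond the scatter). Compound 4 is estimated at 65%, with a range from 40% to 85%.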

Compound 4, a percentage reported as inhibition, at one concentration (the size of the read-out at that concentration, not a potency): 83%
Compound 4: middle estimate off by 18 percentage points, on the low side; the measured number falls inside the stated range.
By their numbers in this assay, from the lowest: compounds 2 and 3 (each within the scatter of the next); then compounds 1 and 4 (each within the scatter of the next).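

In this assay, putting 3,4-dimethoxyphenyl in place of 4-cyanophenyl on a sulfonyl sulfur gives no change at the digits printed from compound 1 to compound 4 (within the scatter). This is the first single-place change shown at this position, and it indicates that, for this pair, the read-out holds when the nitrile is gone and a group of 10 heavy atoms stands where one of 8 stood, so the nitrile is not required to keep this level of inhibition at the one concentration tested. No measurement shown accounts for the two groups reading alike.

On these data alone, what remains open is whether the number in this assay stays level with quite different groups, such as a phenyl ring carrying a carboxylic acid or a primary amine, or a small alkyl chain on the sulfonyl sulfur in place of the aryl ring. A reading at one concentration is also not a potency, so full concentration-response curves would be needed to tell whether compound 1 and compound 4 truly match in strength at the receptor.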